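Replacing two fluorines with a hydroxyl on a weakly active pair

The source may report more compounds than this note shows. Statements on the series, on what has been measured and on what is new or still open speak of the compounds shown alone.

Compound 1, `CCSCCC12CCC(c3nnc(-c4ccccc4C(F)(F)F)n3C)(CC1)CC2`: in an assay on CHO-K1 cells for inhibition of 11-beta-hydroxysteroid dehydrogenase type 2 (Homo sapiens), read by scintillation proximity assay (on this read-out lower numbers stand for stronger inhibition and higher numbers for weaker inhibition), compound 1 gives > 4000 nM, which is a limit of the assay rather than a number.
Compound 2, `Cn1c(-c2ccccc2C(F)(F)F)nnc1C12CCC(CCCC(C)(F)F)(CC1)CC2`: in this assay compound 2 gives > 4000 nM, again a limit and not a number.

Compound 2 therefore stands only at the upper limit of what this assay can read. Among the measured compounds shown here, the single measured step, a step that the two limits leave unreadable from compound 1 to compound 2, cannot be sized, since both of its ends sit at the limit of > 4000 nM in this assay, at which 2 of the 2 values shown sit. For the measured compounds named here, nothing measured so far shows how a change on the side chain moves the read-out.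

Compound 3, `CC(O)CCCC12CCC(c3nnc(-c4ccccc4C(F)(F)F)n3C)(CC1)CC2`, differs from compound 2 by 1-hydroxyethyl in place of 1,1-difluoroethyl on a saturated chain carbon, three bonds along the chain from a saturated ring carbon. Going by the values given here, no measured step bears on this change, so there is no basis for expecting movement beyond the scatter in either direction; the most likely outcome is that compound 3 also returns only a limit. The step from compound 2 to compound 3 is expected to be a step that the limit leaves unreadable from compound 2 to compound 3. Compound 3 is accordingly estimated at 8000 nM, with a range from 2000 nM to 40000 nM.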

Compound 3, half-maximal inhibitory concentration: > 1000 nM
Compound 3: a limit, no number; the forecaster's own chance of this, stated with the estimate: 80%; the middle value lies beyond the limit too.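

Compound 3 also returns only a limit of the assay, not a number, so its steps from compound 1 and from compound 2 cannot be read. The compounds shown leave open how strongly any of the three inhibits in this assay, and whether changing the side chain moves the read-out at all.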